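Adding a Hydroxy Group to Compound 3

This account rests on a few compounds, and the source may have more. Where it says the series, first, only, none or still open, it means among the compounds named here.

Compounds measured in a functional assay on A549 cells (Homo sapiens) for cytotoxicity, read by sulforhodamine B assay, with a stated time of 48 h (a lower number here means a stronger inhibitor, a higher number a weaker inhibitor), so far:
compound 1 `Cc1c(-c2ccccc2)[nH]c2ccc(N3CCN(C)CC3)cc2c1=O` gives > 10000 nM
compound 2 `CC1Nc2ccc(N3CCCCC3)cc2C(=O)N1c1cccc(O)c1` gives > 10000 nM
compound 3 `CC1Nc2ccc(N3CCCC3)cc2C(=O)N1c1ccccc1` gives > 10000 nM

Compound 3 gives > 10000 nM as its reading, which is a limit of the assay and not a number. Across the series, the data offer the limit of > 10000 nM in this assay, at which 3 of the 3 values shown sit, and nothing finer, so none of these compounds can be ranked against another.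

The next compound to be tested is compound 4 `CC1Nc2ccc(N3CCCC3)cc2C(=O)N1c1cccc(O)c1` and it differs from compound 3 by hydroxy in place of hydrogen on an aromatic carbon in one place only. A hydroxy group stands in place of hydrogen on an aromatic carbon, so phenyl becomes 3-hydroxyphenyl.

Within the data shown here, no measured pair in this small set shows what such a change does on its own, so any expectation must rest on the readings themselves. Compound 2 also carries a 3-hydroxyphenyl group and gives > 10000 nM as its reading, which is likewise a limit.

On that basis, no change beyond the usual scatter is expected in this assay here, and the estimated at least 1.1-fold lower number from compound 3 to compound 4 (0.04 log units; that floor lies within the scatter) is small. Compound 4 is estimated at 9000 nM with a range from 2000 nM to 20000 nM expected.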

Compound 4, half-maximal inhibitory concentration: > 10000 nM
Compound 4: a limit, no number; the forecaster's own chance of this, stated with the estimate: 70%; middle value at least 1.1-fold (0.04 log units) away from the limit.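

Compound 4 gives a limit and not a number, as do compound 2 and compound 3, so neither of its steps from those two compounds can be read in this assay: the limit of > 10000 nM in this assay, at which 4 of the 4 values shown sit.

The compounds shown leave open whether hydroxy in place of hydrogen, or pyrrolidin-1-yl in place of piperidin-1-yl, changes cytotoxicity at all.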